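Para substituent on the benzylamide: chloro to methoxy

The source may report more compounds than this note shows. Statements on the series, on what has been measured and on what is new or still open speak of the compounds shown alone.

Measured compounds:
Compound 1 `N[C@H]1CC[C@H](Nc2c(C(=O)NCc3ccc(Cl)cc3)nc(Br)c3cccnc23)CC1` gives 1000 nM.
Compound 2 `N[C@H]1CC[C@H](Nc2c(C(=O)NCc3ccc(Oc4ccccc4)cc3)nc(Br)c3cccnc23)CC1` gives 9000 nM.
Compound 3 `N[C@H]1CC[C@H](Nc2c(C(=O)NCc3ccccn3)nc(Br)c3cccnc23)CC1` reports only a limit, > 20000 nM.

All three were read in a functional assay on HEY cells (Homo sapiens) for cytotoxicity, read by MTT assay, with a stated time of 72 h; on this read-out lower numbers stand for stronger inhibition and higher numbers for weaker inhibition. Compound 1 holds the lowest of the two numbers returned; the nearest measured value comes from compound 2. Both measured changes touch the benzylamide arm of the shared core and both weaken the result. Putting phenoxy in place of chloro gives a 9.0-fold higher number from compound 1 to compound 2 (0.95 log units; beyond the scatter). Putting pyridin-2-yl in place of 4-chlorophenyl gives an at least 20-fold higher number from compound 1 to compound 3 (1.30 log units; beyond the scatter), where the value of compound 3 is the limit of > 20000 nM in this assay, at which 1 of the 3 values shown sits.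

Compound 4 `COc1ccc(CNC(=O)c2nc(Br)c3cccnc3c2N[C@H]2CC[C@H](N)CC2)cc1` differs from compound 1 in one place: methoxy in place of chloro on an aromatic carbon. Of the two measured steps, the phenoxy step is the closer comparison, since it too keeps the aromatic ring and alters only the group para to the large group, while the pyridyl step exchanges the ring itself. A loss in the same direction but of smaller size than the phenoxy step is expected. Compound 4 is therefore expected to give 2500 nM, with a range of 800 nM to 8000 nM. For compound 4 this expectation amounts to a 2.5-fold higher number from compound 1 to compound 4 (0.40 log units; beyond the scatter).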

Compound 4, half-maximal inhibitory concentration: 4000 nM
Beside the measured number, compound 4's estimate is 1.6-fold (0.20 log units) below it; the measured number falls inside the stated range.
By their numbers in this assay, from the lowest: compound 1; then compound 4; then compound 2. At a limit, above all of these: compound 3.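

In this assay, methoxy on the aromatic carbon para to a large group also weakens the result, with a 4.0-fold higher number from compound 1 to compound 4 (0.60 log units; beyond the scatter), so this position has now lost ground with both oxygen-linked groups tried in place of chloro. The loss differs between those two groups: methyl in place of phenyl on the oxygen gives a 2.3-fold lower number from compound 2 to compound 4 (0.35 log units; beyond the scatter), so an oxygen at this place does not set the outcome by itself. The 4-methoxyphenyl arm also improves on the pyridin-2-yl arm, with an at least 5.0-fold lower number from compound 3 to compound 4 (0.69 log units; beyond the scatter), and this step rests on a limit for compound 3: the limit of > 20000 nM in this assay, at which 1 of the 4 values shown sits.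

From the compounds shown here alone, it remains open whether fluoro, bromo or methyl at this place would match chloro. Also open, going by these compounds, is how a hydroxyl, an amine or a carboxylic acid would behave there.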